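The compounds below may be only part of what the source reports. "The series", "measured", "known", "first", "only" and "open" are said of these compounds alone.

Compound 3 `C#CCOCC(N)C(=O)NCc1ccccc1` gives 46 mg/kg in a functional assay on the whole organism (strain NMRI) with Mus musculus as the target, in the maximal electroshock model, with a stated time of 30 min; on this read-out lower numbers stand for an effect already at smaller amounts and higher numbers for an effect only at larger amounts of compound. Compound 1 `CCCC(N)C(=O)NCc1ccccc1` gives 39 mg/kg and compound 2 `C=CCOCC(N)C(=O)NCc1ccccc1` gives 45 mg/kg; the three numbers lie within the scatter of one another, so compound 3 stands level with both. The measured steps are a 1.2-fold higher number from compound 1 to compound 2 (0.06 log units; within the scatter), a 1.2-fold higher number from compound 1 to compound 3 (0.07 log units; within the scatter) and a 1.0-fold higher number from compound 2 to compound 3 (0.01 log units; within the scatter), each within the scatter. Compound 4 `CN(C)CC(N)C(=O)NCc1ccccc1` is not yet measured. dimethylamino in place of propargyloxy on a saturated chain carbon, two bonds along the chain from an amine nitrogen and a carbonyl carbon All three measured steps vary the group at this same place, from ethyl to allyloxy to propargyloxy, and none moves the number beyond the scatter. Among the compounds with values here, no measured step, however, replaces propargyloxy with dimethylamino, so that exchange has no precedent. On the evidence at hand the step to compound 4 is expected to be small, a 1.1-fold higher number from compound 3 to compound 4 (0.04 log units; within the scatter), with no direction favoured and a wider range allowed for the untested group. Compound 4 is therefore estimated at 50 mg/kg in this assay, within 22 mg/kg to 115 mg/kg.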

Compound 4, dose for half-maximal effect: 94 mg/kg
Compound 4: middle estimate off by 1.9-fold (0.27 log units), on the low side, and the stated range covers the measured number.
By their numbers in this assay, from the lowest: compounds 1, 2 and 3 (each within the scatter of the next); then compound 4.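

In this assay this place now shows steps beyond the scatter, a 2.0-fold higher number from compound 3 to compound 4 (0.31 log units; beyond the scatter) and a 2.1-fold higher number from compound 2 to compound 4 (0.32 log units; beyond the scatter) and a 2.4-fold higher number from compound 1 to compound 4 (0.38 log units; beyond the scatter), all of them modest. Ethyl, allyloxy and propargyloxy had stood level with one another, so the number at this saturated chain carbon does depend on the group it carries, and among the four compounds dimethylamino alone stands apart, with none going against this. Nothing measured here speaks to what lies behind the shift.

Open, on these data alone, is whether the higher number belongs to amines at this place in general or to dimethylamino alone; methylamino, diethylamino or a pyrrolidine ring would bear on that. Also open, as far as these compounds go, is how a plain methoxy group, or a longer chain in place of ethyl, would compare with the level set by compounds 1, 2 and 3.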